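A tert-butyl to 4-bromophenyl swap, tested a second time

The compounds below may be only part of what the source reports. "The series", "measured", "known", "first", "only" and "open" are said of these compounds alone.

Compound 1, `CC(C)(C)c1cc(NC(=O)Nc2cc(C(F)(F)F)cc(C(F)(F)F)c2)n(C(C)(C)C)n1`: 0.5 degrees C
Compound 2, `CC(C)(C)c1cc(NC(=O)Nc2cc(C(F)(F)F)cc(C(F)(F)F)c2)n(-c2ccc(Br)cc2)n1`: 0.3 degrees C
Compound 3, `CC(C)(C)c1cc(NC(=O)Nc2cc(F)cc(F)c2)n(C(C)(C)C)n1`: 0 degrees C

These three compounds were tested in an assay on isolated protein for inhibition of Ephrin type-A receptor 2 (Homo sapiens), read by thermal shift assay, tested at 10 uM; a higher number here means that the compound stabilises the target more against heat, a lower number that the compound stabilises the target less. All three give small readings, and every gap between them is within the scatter of the measurement, so none of the three can be called a better or worse stabiliser than the others.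

Compound 1 and compound 2 share a core and differ in one place: 4-bromophenyl in place of tert-butyl on an aromatic nitrogen. Going from one to the other gives a number 0.20 degrees C lower from compound 1 to compound 2 (within the scatter), a step that is within the scatter and so tells of no real change.

Compound 3 carries a different core; the difference between the core of compound 3 and the core of compound 1 is not broken down here. Compound 4, `CC(C)(C)c1cc(NC(=O)Nc2cc(F)cc(F)c2)n(-c2ccc(Br)cc2)n1`, is not yet measured. It differs from compound 3 by 4-bromophenyl in place of tert-butyl on an aromatic nitrogen, the same change that turns compound 1 into compound 2, with the surroundings of the place described in the same words.

In this assay the step expected is a number 0.10 degrees C lower from compound 3 to compound 4 (within the scatter), because the same change gave a number 0.20 degrees C lower from compound 1 to compound 2 (within the scatter) and compound 3 starts from a reading as small as the others. Compound 4 is therefore estimated to give about -0.1 degrees C, with a range from -1 degrees C to 0.8 degrees C.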

Compound 4, shift of the target's melting temperature: 1.3 degrees C
Estimate against measurement, compound 4: 1.4 degrees C below, and the stated range ends below it.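

Placing 4-bromophenyl in place of tert-butyl on an aromatic nitrogen did not have the same outcome on both cores in this assay, where the change gave a number 1.3 degrees C higher from compound 3 to compound 4 (beyond the scatter), and the two steps clearly part ways: the same change on two cores in this assay, a number 0.20 degrees C lower (within the scatter) from compound 1 to compound 2 and a number 1.3 degrees C higher (beyond the scatter) from compound 3 to compound 4, 1.5 degrees C apart, beyond the scatter of two such steps. On this evidence, the step seen on one of these cores is a poor guide to the step on the other, so the result of this swap has to be measured on each of the two rather than carried across. Among the compounds shown here, the numbers do not show which feature of the two cores lies behind the difference, nor how the same swap would behave on a third core, since only two pairs of compounds are available.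

The compounds shown leave open whether other groups on that aromatic nitrogen, such as an unsubstituted phenyl, a 4-chlorophenyl or a longer alkyl chain, would follow the step seen with compound 4 or the one seen with compound 2. They also leave open how the readings would respond if an amine or a carboxylic acid were placed on the phenyl ring of the urea.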